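Swapping the Phenyl Group on a Carbonyl Carbon

The compounds below may be only part of what the source reports. "The series", "measured", "known", "first", "only" and "open" are said of these compounds alone.

In a functional assay on Ehrlich cells (Mus musculus) for cytotoxicity, read by LDH release, with a stated time of 48 h (a higher number here means a weaker inhibitor, a lower number a stronger inhibitor), compound 1 `Cc1ccc(OCC(=O)NNC(=O)c2cc3ccccc3oc2=O)c(C(=O)c2cccc(Cl)c2)c1` reads 65400 nM and compound 2 `Cc1ccc(OCC(=O)NNC(=O)c2cc3ccccc3oc2=O)c(C(=O)c2ccccc2Cl)c1` reads 47600 nM while compound 3 `Cc1ccc(OCC(=O)NNC(=O)c2cc3ccccc3oc2=O)c(C(=O)c2ccc(F)cc2)c1` reads 40800 nM here, so compound 1 sits within the scatter of both others. Compound 4 `Cc1ccc(C(=O)c2cc(C)ccc2OCC(=O)NNC(=O)c2cc3ccccc3oc2=O)cc1` is still unmeasured. It carries 4-methylphenyl in place of 3-chlorophenyl on a carbonyl carbon. The closest guides replace the same group at the same place: a 1.4-fold lower number from compound 1 to compound 2 (0.14 log units; within the scatter) and a 1.6-fold lower number from compound 1 to compound 3 (0.20 log units; within the scatter) are both within the scatter, as is a 1.2-fold lower number from compound 2 to compound 3 (0.07 log units; within the scatter) between them. None of these compounds holds a 4-methylphenyl group, so the comparison is only indirect. No step beyond the scatter is therefore expected, and the estimated step of a 1.4-fold lower number from compound 1 to compound 4 (0.13 log units; within the scatter) stays small. In this assay compound 4 is estimated at 48000 nM with 28000 nM to 82000 nM as its likely range.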

Compound 4, half-maximal inhibitory concentration: 81400 nM
The estimate for compound 4 lay 1.7-fold (0.23 log units) below the measured number; low and high end bracket the measured number.
By their numbers in this assay, from the lowest: compounds 3, 2, 1 and 4 (each within the scatter of the next).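

In this assay, a 1.2-fold higher number from compound 1 to compound 4 (0.10 log units; within the scatter) and a 1.7-fold higher number from compound 2 to compound 4 (0.23 log units; within the scatter) and a 2.0-fold higher number from compound 3 to compound 4 (0.30 log units; within the scatter) all stay within the scatter. A ring carrying methyl and no halogen therefore reads like the rings carrying chloro or fluoro, so all four phenyl groups on this carbonyl carbon give equivalent numbers.

On these data alone, whether any group here can move the number beyond the scatter remains open. A phenyl ring bearing an amine or a carboxylic acid, or a longer chain in place of the ring, would test this. No measurement shown offers an explanation for these readings.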